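Benzoyl Esters of a Chloropurine Diol: Cytotoxicity in Hepatoma Cells

The compounds below may be only part of what the source reports. "The series", "measured", "known", "first", "only" and "open" are said of these compounds alone.

Measured compounds:
Compound 1 `O=C(OC[C@H]1C[C@@H](n2cnc3c(Cl)ncnc32)[C@@H]1CO)c1ccccc1` — 20000 nM
Compound 2 `OC[C@H]1C[C@@H](n2cnc3c(Cl)ncnc32)[C@@H]1CO` — > 200000 nM
Compound 3 `OCC(CO)CCn1cnc2c(Cl)ncnc21` — > 200000 nM

In an ADME assay on Huh-7 cells (Homo sapiens) for cytotoxicity, read by XTT assay (a lower number here means that less compound is tolerated, a higher number that more compound is tolerated), compound 2 reaches only the limit of the measurement, > 200000 nM. Compound 1 gives 20000 nM in this assay, a step of an at least 10-fold lower number from compound 2 to compound 1 (1.00 log units; beyond the scatter) that follows the change (benzoyl in place of hydrogen on an oxygen on a saturated carbon). Compound 3 likewise reports only a limit in this assay, > 200000 nM; the difference between the core of compound 3 and the core of compound 2 is not broken down here.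

Compound 4 `O=C(OCC(CO)CCn1cnc2c(Cl)ncnc21)c1ccccc1` is not yet measured. It differs from compound 3 by benzoyl in place of hydrogen on an oxygen on a saturated carbon, the same change as from compound 2 to compound 1, at a place described in identical words. Compound 4 is therefore expected to show a step of an at least 6.6-fold lower number from compound 3 to compound 4 (0.82 log units; beyond the scatter), resting on the step of an at least 10-fold lower number from compound 2 to compound 1 (1.00 log units; beyond the scatter) that follows the same change, and on (the limit of > 200000 nM in this assay, at which 2 of the 3 values shown sit). Compound 4 is estimated at 30000 nM, within 8000 nM and 200000 nM.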

Compound 4, half-maximal cytotoxic concentration: 108000 nM
Compound 4: middle estimate off by 3.6-fold (0.56 log units), on the low side, and the stated range covers the measured number.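

Carried to the second core, benzoyl in place of hydrogen on an oxygen on a saturated carbon gives an at least 1.8-fold lower number from compound 3 to compound 4 (0.26 log units; that floor lies within the scatter) in this assay. Compound 3 gives > 200000 nM, which is a limit of the assay. The change can thus be set beside its earlier step on the other core, but this does not show that it carries over with the same size, nor that its size depends on the core: the same change on two cores in this assay, an at least 10-fold lower number (1.00 log units; beyond the scatter) from compound 2 to compound 1 and an at least 1.8-fold lower number (0.26 log units; that floor lies within the scatter) from compound 3 to compound 4; the limit leaves it open whether they differ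

The compounds shown leave open whether an acetyl group or a longer chain on the same oxygen would behave as benzoyl does. They also leave open what a second benzoyl on the remaining hydroxyl would give.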